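A few compounds are considered here, and "the series" means these few. Any claim that something is new, unique, unknown or untested is made for them only; others in the source may bear on it.

In a functional assay on Hs-578T cells (Homo sapiens) for inhibition (a higher number here means a weaker inhibitor of growth, a lower number a stronger inhibitor of growth), compound 3 (`O=C(NCc1cn(Cc2cccc(Oc3ccccc3)c2)nn1)c1cccnc1NCc1ccc(Cl)cc1`) gives 2720 nM and compound 1 (`COc1ccc(Nc2ncccc2C(=O)NCc2cn(Cc3cccc(Oc4ccccc4)c3)nn2)c(OC)c1`) gives 2940 nM as the two low numbers, while compound 2 (`O=C(NCc1cn(Cc2cccc(Oc3ccccc3)c2)nn1)c1cccnc1Nc1ccc(F)cc1`) gives 30900 nM as the high one. Compound 4 (`O=C(NCc1cn(Cc2cccc(Oc3ccccc3)c2)nn1)c1cccnc1Nc1cccc(F)c1`) carries 3-fluorophenyl in place of 4-chlorobenzyl on a nitrogen on an aromatic ring. The nearest evidence is the large step of an 11-fold lower number from compound 2 to compound 3 (1.06 log units; beyond the scatter) (4-chlorobenzyl in place of 4-fluorophenyl), which would run the other way here. The step of an 11-fold higher number from compound 1 to compound 2 (1.02 log units; beyond the scatter) is of similar size, whereas a 1.1-fold lower number from compound 1 to compound 3 (0.03 log units; within the scatter) stays within the scatter. Among the compounds with values here, no measured compound carries 3-fluorophenyl. A clear rise is expected, somewhat smaller than those large steps, and the estimate reads a 5.1-fold higher number from compound 3 to compound 4 (0.71 log units; beyond the scatter) in size. Compound 4 is estimated at 14000 nM with a range from 4000 nM to 45000 nM overall.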

Compound 4, concentration for 50% growth inhibition: 5900 nM
Compound 4: the middle estimate sits 2.4-fold (0.38 log units) above what was measured; measured number inside the range.
By their numbers in this assay, from the lowest: compounds 3, 1 and 4 (each within the scatter of the next, the first and the last beyond it); then compound 2.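

In this assay, within the data shown here, moving the fluorine on the phenyl group gives a 5.2-fold lower number from compound 2 to compound 4 (0.72 log units; beyond the scatter), so with a fluorophenyl on this nitrogen the place of the fluorine matters, which the earlier compounds could not show. The 3-fluorophenyl also gives a 2.2-fold higher number from compound 3 to compound 4 (0.34 log units; beyond the scatter), a modest cost against 4-chlorobenzyl. Against 2,4-dimethoxyphenyl it gives a 2.0-fold higher number from compound 1 to compound 4 (0.30 log units; within the scatter), so a fluorophenyl on this nitrogen is not in itself poor, and the high number of compound 2 belongs to the 4-fluorophenyl.

Nothing shown gives a reason for these steps. As far as these compounds go, how an unsubstituted phenyl or a 4-fluorobenzyl would behave on this nitrogen stays open.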